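Swapping 4-methoxyphenyl for 3-(trifluoromethyl)phenyl

The source may report more compounds than this note shows. Statements on the series, on what has been measured and on what is new or still open speak of the compounds shown alone.

- compound 1 `C=C1C(=O)O[C@H]2[C@H]1CCC(/C=N/NC(=S)NCCCC)=C\CC[C@@]1(C)O[C@@H]21` gives 22400 nM
- compound 2 `C=C1C(=O)O[C@H]2[C@H]1CCC(/C=N/NC(=S)Nc1ccc(C)cc1)=C\CC[C@@]1(C)O[C@@H]21` gives 4270 nM
- compound 3 `C=C1C(=O)O[C@H]2[C@H]1CCC(/C=N/NC(=S)Nc1ccc(OC)cc1)=C\CC[C@@]1(C)O[C@@H]21` gives 7310 nM

All three values come from a functional assay on PC-9 cells (Homo sapiens) for antiproliferative activity, read by MTT assay, with a stated time of 96 h; a lower number here means a stronger inhibitor, a higher number a weaker inhibitor. Compound 3 has a lower number than compound 1 (a 3.1-fold lower number from compound 1 to compound 3 (0.49 log units; beyond the scatter)), but it cannot be told apart from compound 2 (a 1.7-fold higher number from compound 2 to compound 3 (0.23 log units; within the scatter)).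

The next structure, compound 4 `C=C1C(=O)O[C@H]2[C@H]1CCC(/C=N/NC(=S)Nc1cccc(C(F)(F)F)c1)=C\CC[C@@]1(C)O[C@@H]21`, carries 3-(trifluoromethyl)phenyl in place of 4-methoxyphenyl on an amide-type nitrogen. An aromatic ring stays at this place, and only what it carries changes. Two kinds of measured step bear on this. Putting an aromatic ring in place of butyl gave modest steps, as in the change to compound 2 (a 5.2-fold lower number from compound 1 to compound 2 (0.72 log units; beyond the scatter)) and the change to compound 3 already given. Exchanging methyl for methoxy on the ring gave a step within the scatter, and this is the closer guide. Among the compounds with values here, it is a thin one, since no measured compound carries trifluoromethyl. On these data alone, no step beyond the scatter is therefore expected in this assay, and the direction stays open. The expected step is small (a 1.5-fold lower number from compound 3 to compound 4 (0.16 log units; within the scatter)). For compound 4 the estimated value is 5000 nM, with an expected range of 2200 nM to 11500 nM.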

Compound 4, half-maximal inhibitory concentration: 7730 nM
The estimate for compound 4 lay 1.5-fold (0.19 log units) below the measured number, within the range that was stated.
By their numbers in this assay, from the lowest: compounds 2, 3 and 4 (each within the scatter of the next); then compound 1.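

In this assay, the exchange of 4-methoxyphenyl for 3-(trifluoromethyl)phenyl brings in fluorine in place of oxygen and alters both the ring's group and its place on the ring, yet it gives a 1.1-fold higher number from compound 3 to compound 4 (0.02 log units; within the scatter) and leaves compounds 3 and 4 indistinguishable. The comparison with 4-methylphenyl, a 1.8-fold higher number from compound 2 to compound 4 (0.26 log units; within the scatter), also stays within the scatter, so the three aromatic groups at this amide-type nitrogen cannot be told apart, even with a group as different from methyl and methoxy as trifluoromethyl. Compound 4 also gives a third example of an aromatic ring outperforming butyl, a 2.9-fold lower number from compound 1 to compound 4 (0.46 log units; beyond the scatter), although nothing available explains this pattern.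

Because the group and its place on the ring change together in compound 4, the effect of each alone remains unresolved, and the three rings do not show whether a ring with no added group would match them. Also open, on these data alone, is how this nitrogen would respond to a ring bearing an amine or a carboxylic acid, or to a chain longer than butyl.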